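A few compounds are considered here, and "the series" means these few. Any claim that something is new, unique, unknown or untested is made for them only; others in the source may bear on it.

Measured compounds:
compound 1 `CC(Sc1nc2c(cnn2C)c(=O)n1-c1ccccc1)c1cccc(F)c1`, 110 nM in an assay on isolated protein for inhibition of retinal dehydrogenase 2 (Homo sapiens); a lower number here means a stronger inhibitor, a higher number a weaker inhibitor
compound 2 `CC(Sc1nc2c(cnn2C)c(=O)n1-c1ccccc1)c1ccccc1`, 110 nM

Compound 2 stands level with compound 1 in this assay; the step of no change at the digits printed from compound 1 to compound 2 (within the scatter) lies within the scatter of repeated measurements. Compound 3 `CC(Sc1nc2c(cnn2C)c(=O)n1-c1ccc(CCO)cc1)c1ccccc1` has not yet been measured. It differs from compound 2 by 2-hydroxyethyl in place of hydrogen on an aromatic carbon on the ring attached to the shared core. Among the measured compounds shown here, the one measured step, from compound 1 to compound 2, concerns a hydrogen in place of fluoro on the other ring, a different place from the change leading to compound 3, so no measured step bears directly on the new change; the single step that exists was flat. With nothing in the data pointing either way, the expected step of no change at the digits printed from compound 2 to compound 3 (within the scatter) for compound 3 is none beyond the scatter, with a broad range to allow for an unsampled place of substitution. Compound 3 is estimated at 110 nM, within 40 nM to 400 nM in this assay.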

Compound 3, half-maximal inhibitory concentration: 216 nM
Beside the measured number, compound 3's estimate is 2.0-fold (0.29 log units) below it, within the range that was stated.
By their numbers in this assay, from the lowest: compounds 1, 2 and 3 (each within the scatter of the next).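

Among the compounds shown here, on the ring attached to the shared core, which carried no substituent in the earlier compounds, a 2-hydroxyethyl group now stands para to a large group, and in this assay the step is a 2.0-fold higher number from compound 2 to compound 3 (0.29 log units; within the scatter). This position therefore tolerates this chain with no difference that can be told from the scatter, whereas the earlier step, no change at the digits printed from compound 1 to compound 2 (within the scatter), spoke only for the other ring. No available data explain the result at this position.

From the compounds shown here alone, whether a longer chain, an amine or a carboxylic acid at the same place would also stay level with compound 2 remains open, as does whether an ethyl group would read the same as the 2-hydroxyethyl group. Whether this holds at other places on this ring is also unanswered.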